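Methoxy for trifluoromethyl on the pendant aryl ring

This account rests on a few compounds, and the source may have more. Where it says the series, first, only, none or still open, it means among the compounds named here.

Compound 1 `CCC1=C(O)c2c(oc(-c3ccc(C(F)(F)F)cc3)cc2=O)C(CC)(CC)C1=O` carries a trifluoromethyl group on its aryl ring; in a functional assay on KB cells (Homo sapiens) for antiproliferative activity, read by sulforhodamine B assay, with a stated time of 3 days (on this read-out lower numbers stand for an effect already at smaller amounts and higher numbers for an effect only at larger amounts of compound), compound 1 gives 35.7 uM. Compound 2 `CCC1=C(O)c2c(oc(-c3ccc(OC)cc3)cc2=O)C(CC)(CC)C1=O` differs from it by methoxy in place of trifluoromethyl on an aromatic carbon, and in this assay compound 2 gives 17.7 uM, a step of a 2.0-fold lower number from compound 1 to compound 2 (0.30 log units; within the scatter). Compound 3 `CCC1=C(O)c2c(oc(-c3cccc(C(F)(F)F)c3)cc2=O)C(CC)(CC)C1=O` has the same atoms as compound 1 joined differently; the difference between the two cores is not broken down here. In this assay compound 3 gives 35.7 uM, level with compound 1 at the digits printed.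

Compound 4 `CCC1=C(O)c2c(oc(-c3cccc(OC)c3)cc2=O)C(CC)(CC)C1=O` is not yet measured. It differs from compound 3 by methoxy in place of trifluoromethyl on an aromatic carbon, the same kind of change as that from compound 1 to compound 2, but here the place is meta to a large group rather than para to a large group. Because the earlier step was a 2.0-fold lower number from compound 1 to compound 2 (0.30 log units; within the scatter), a step of similar size is expected here, a 1.6-fold lower number from compound 3 to compound 4 (0.21 log units; within the scatter). Compound 4 is therefore expected at about 22 uM, between 9 uM and 55 uM.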

Compound 4, concentration for half-maximal effect: 13.3 uM
For compound 4 the middle estimate is 1.7-fold (0.22 log units) above the measured one; the measured number falls inside the stated range.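

In this assay the change of methoxy in place of trifluoromethyl carries over from one core to the other with no gap beyond the scatter: the same change on two cores in this assay, a 2.0-fold lower number (0.30 log units; within the scatter) from compound 1 to compound 2 and a 2.7-fold lower number (0.43 log units; beyond the scatter) from compound 3 to compound 4, 1.3-fold (0.12 log units) apart, within the scatter of two such steps. The new step on its own, a 2.7-fold lower number from compound 3 to compound 4 (0.43 log units; beyond the scatter), is modest, and two pairs give the same direction without showing that the step would hold on any further core. The two methoxy compounds themselves do not separate in this read-out (a 1.3-fold lower number from compound 2 to compound 4 (0.12 log units; within the scatter)).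

Open, as far as these compounds go, is whether the step holds when the group on the aryl ring is an amine, a carboxylic acid or a longer chain. Also open, from the compounds shown here alone, is how far the shared core can change before the step no longer carries over.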